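This account rests on a few compounds, and the source may have more. Where it says the series, first, only, none or still open, it means among the compounds named here.

In a functional assay on HeLa cells (Homo sapiens) for antiproliferative activity, read by sulforhodamine B assay, with a stated time of 72 h (on this read-out higher numbers stand for weaker inhibition and lower numbers for stronger inhibition), compound 1 `Cc1cccc(NC(=S)N/N=C/c2ccc3ccccc3n2)c1` gives > 100000 nM as its result, which is a limit of the assay and not a number. For the measured compounds named here, compound 2 `Cc1ccc(NC(=S)N/N=C/c2ccc3ccccc3n2)cc1` gives 86000 nM and so holds the only true number so far, with no other number to rank it against. Going by the values given here, the one measured step is an at least 1.1-fold lower number from compound 1 to compound 2 (0.06 log units; that floor lies within the scatter) and concerns where a methyl group sits, not what replaces it, so it offers only a loose guide. Compound 3 `S=C(N/N=C/c1ccc2ccccc2n1)Nc1ccc(Cl)cc1` keeps the shared core and changes one group, 4-methylphenyl to 4-chlorophenyl: chloro in place of methyl on an aromatic carbon amounts to chloro in place of methyl on an aromatic carbon, para to a large group. Among the compounds with values here, no exchange of this kind has been measured yet, and the only step stays within the scatter at its floor. No clear shift beyond the scatter is therefore expected in this assay and a result in the same high range seems likeliest. The expected step is a 1.7-fold lower number from compound 2 to compound 3 (0.24 log units; within the scatter) on this estimate. For compound 3 the estimated value is 50000 nM with 12000 nM to 120000 nM as the expected span.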

Compound 3, half-maximal inhibitory concentration: > 100000 nM
Compound 3 gave a limit, no number; the forecaster's own chance of this, stated with the estimate: 20%; middle value at least 2.0-fold (0.30 log units) from the limit.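

In this assay compound 3 gives > 100000 nM, which is a limit of the assay and not a number. For the compounds shown here, until now the only change measured was a methyl group moved to another place on the ring, whereas here one group is exchanged for another at a single place, para to a large group: chloro in place of methyl gives an at least 1.1-fold higher number from compound 2 to compound 3 (0.06 log units; that floor lies within the scatter), so this exchange brings no sign of stronger inhibition, and its true size stays unknown, with only a floor that lies within the scatter. The step from compound 1 to compound 3 cannot be read, and most of this small set now sits at one ceiling, where differences between compounds no longer show: the limit of > 100000 nM in this assay, at which 2 of the 3 values shown sit.

Going by these compounds alone, compound 2 remains the only compound with a true number, so how far compound 3 really lies from it stays open. Also open, going by these compounds, is what an amine, a carboxylic acid or a longer chain at this same place would do to the number, and whether any group here could bring it well below the values seen so far.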